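Adding a methylimidazole to the core: expected plasma exposure

The source may hold more compounds than are shown below. What is called first, only, known or untested is meant among the compounds shown, and "the series" means these compounds.

Measured compounds:
compound 1, `CCCCN(c1nc2ccccc2o1)[C@H](C)c1ccc(-c2ccccc2-c2nnn[nH]2)cc1`: 29.2 nM
compound 2, `CCCCN(c1nc2c(C(=O)O)cccc2o1)[C@H](C)c1ccc(-c2cc(Cl)ccc2-c2nc(=O)o[nH]2)cc1`: 677 nM

Both were tested in an ADME assay on the whole organism (Macaca fascicularis) for pharmacokinetics, read by LC-MS, using cassette dosing, at a dose of 1 mg/kg by the oral route; a higher number here means more compound in the circulation at the dose given, a lower number less compound in the circulation. Compound 1 gives 29.2 nM, the lower of the two numbers. Compound 2 gives 677 nM, a considerably higher number, and the gap between them lies beyond the usual scatter. The two differ in several places at once, so the values show only that these two molecules reach different plasma levels, nothing about which part is responsible.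

Compound 3, `CCCCN(c1nc2c(-c3nccn3C)cccc2o1)[C@H](C)c1ccc(-c2ccccc2-c2nnn[nH]2)cc1`, has not yet been measured. It differs from compound 1 in one place: 1-methyl-1H-imidazol-2-yl in place of hydrogen on an aromatic carbon. Among the measured compounds shown here, no measured pair traces exactly this change, so the size of the step can only be guessed from the position of compound 1 alone.

The expected change from compound 1 to compound 3 in this assay is a 1.5-fold higher number from compound 1 to compound 3 (0.19 log units; within the scatter), a small rise that may well fall within the scatter. Compound 3 is therefore expected to give about 45 nM, with a plausible range from 10 nM to 200 nM.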

Compound 3, maximal plasma concentration: 154 nM
Estimate against measurement, compound 3: 3.4-fold (0.53 log units) below; the measured number falls inside the stated range.
By their numbers in this assay, from the lowest: compound 1; then compound 3; then compound 2.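

In this assay, among the compounds shown here, replacing hydrogen with 1-methyl-1H-imidazol-2-yl on an aromatic carbon of the shared core gives a 5.3-fold higher number from compound 1 to compound 3 (0.72 log units; beyond the scatter) and is the first change here that can be read on its own, since the earlier pair differed in several places at once. The step is modest but lies beyond the scatter, so this carbon can carry a five-membered aromatic ring with 6 heavy atoms and the maximal plasma concentration still rises rather than falls on the background of compound 1. Nothing measured alongside this result explains why the number rises, so the step describes the outcome and not its cause.

The compounds shown leave open whether the rise needs this particular ring, as a plain imidazole without the methyl, a nitrile or a methoxy group on the same carbon would be needed to tell. They also leave open whether the same change gives a similar step on other backgrounds, since a single pair shows its effect only on the core of compound 1.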